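A few compounds are considered here, and "the series" means these few. Any claim that something is new, unique, unknown or untested is made for them only; others in the source may bear on it.

Within the data shown here, in an ADME assay on Vero cells (Chlorocebus sabaeus) for cytotoxicity, read by MTT assay (a higher number here means a weaker inhibitor, a lower number a stronger inhibitor), compound 1 `C=CCOc1cc(OC)c(C(=O)/C=C/c2ccccc2)c(OCC=C)c1` gives 17100 nM, and this is the only number available so far. Compound 2 `C=CCOc1cc(OC)c(C(=O)/C=C/c2ccc(O)c(OC)c2)c(OCC=C)c1` has no place on that scale: the entry for compound 2 reads "not determined" (no result reported), so it offers no single value to start from. Compound 3 `C=CCOc1cc(OC)c(C(=O)/C=C/c2ccc(Cl)cc2)c(OCC=C)c1` has not yet been measured. The structural change is 4-chlorophenyl in place of 4-hydroxy-3-methoxyphenyl on a double-bonded chain carbon bound to a double-bonded chain carbon. Among the measured compounds shown here, with no number at the starting end, this change cannot be sized from measurement, and no measured pair of similar compounds shows what such a swap might do. The best remaining guide is compound 1 at 17100 nM, and compound 3 is expected to land near it, with no shift beyond the usual scatter in either direction. The estimated value for compound 3 is 15000 nM, with an expected range of 6000 nM to 40000 nM.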

Compound 3, half-maximal inhibitory concentration: 10400 nM
Estimate against measurement, compound 3: 1.4-fold (0.16 log units) above, within the range that was stated.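

In this assay chloro in place of hydrogen on an aromatic carbon gives a 1.6-fold lower number from compound 1 to compound 3 (0.22 log units; within the scatter) and so offers the first measured view of a change on this ring. The step stays within the scatter, so this one swap gives no sign that chloro on the ring alters the read-out, while the swap from 4-hydroxy-3-methoxyphenyl to 4-chlorophenyl cannot be read, as compound 2 has no number. Nothing measured here offers an explanation for this result.

Still open, on these data alone, is whether a different group on the same ring, such as an amine or a carboxylic acid, would shift the number beyond the scatter. Also open, as far as these compounds go, is what the hydroxy and methoxy groups of compound 2 contribute to this read-out.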